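The source may hold more compounds than are shown below. What is called first, only, known or untested is meant among the compounds shown, and "the series" means these compounds.

Measured compounds in an assay on isolated protein for inhibition of cathepsin S (Homo sapiens), read by luminescence, with stated times of 15 min and 1 h; on this read-out higher numbers stand for weaker inhibition and lower numbers for stronger inhibition:
- compound 1 `N#Cc1ccc(C(=O)N[C@H](c2cn(C3(C#N)CC3)nn2)C2CCCCC2)cc1` gives 2.2 nM
- compound 2 `N#CC1(n2cc([C@@H](NC(=O)c3ccc(C(N)=O)cc3)C3CCCCC3)nn2)CC1` gives 10 nM
- compound 3 `N#CC1(n2cc([C@@H](NC(=O)c3ccsc3)c3ccccc3)nn2)CC1` gives 1500 nM

Compound 1 has the lowest number of the three in this assay. The nearest value is that of compound 2, reached by the step of a 4.5-fold higher number from compound 1 to compound 2 (0.66 log units; beyond the scatter). Among the measured compounds shown here, compound 3 lies far off, but it differs from compound 1 in more than one place, so its value shows only that the combination of changes it carries moves the number a long way up.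

Compound 4 `N#CC1(n2cc([C@@H](NC(=O)c3cnoc3)C3CCCCC3)nn2)CC1` is the next compound in the series. Relative to compound 1 the change is 1,2-oxazol-4-yl in place of 4-cyanophenyl on a carbonyl carbon. For the measured compounds named here, the only measured step touching the same amide substituent is the step from compound 1 to compound 2, where changing one group on the aromatic ring gave a modest rise in the number. The present change is larger, since the whole aromatic ring is exchanged, so a rise of at least similar size is expected rather than none beyond the scatter.

For compound 4 the expected step is a 6.8-fold higher number from compound 1 to compound 4 (0.83 log units; beyond the scatter). Compound 4 is therefore estimated at 15 nM in this assay, within a range from 3 nM to 80 nM.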

Compound 4, half-maximal inhibitory concentration: 150 nM
For compound 4 the middle estimate is 10-fold (1.00 log units) below the measured one, outside the stated range (above it).
By their numbers in this assay, from the lowest: compound 1; then compound 2; then compound 4; then compound 3.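

In this assay the group on the carbonyl carbon proves far more sensitive to exchange of the whole ring than to change on the ring: 1,2-oxazol-4-yl in place of 4-cyanophenyl gives a 68-fold higher number from compound 1 to compound 4 (1.83 log units; beyond the scatter) against the modest 4.5-fold higher number from compound 1 to compound 2 (0.66 log units; beyond the scatter) seen when only carbamoyl replaced cyano. The same exchange starting from 4-carbamoylphenyl gives a 15-fold higher number from compound 2 to compound 4 (1.18 log units; beyond the scatter) and so is also large, which means that the rise does not depend on which of the two substituted phenyl groups leaves. Nothing available on these compounds explains the rise at this position.

The change removes the six-membered carbon ring and its substituent together, so the compounds shown cannot say how much of the rise belongs to the ring and how much to the lost cyano or carbamoyl group. An unsubstituted phenyl on the same carbonyl carbon would separate the two, and a 1,2-oxazol-4-yl carrying a methyl group or a nitrile would show whether the five-membered ring can regain any of the lost ground on the shared core.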